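Methoxy on the distal phenyl of the biphenyl series

This account rests on a few compounds, and the source may have more. Where it says the series, first, only, none or still open, it means among the compounds named here.

Measured compounds:
compound 1, `Cc1ccccc1-n1nc(C)c2c1NC(=O)[C@H](C)S[C@@H]2c1ccc(-c2ccccc2)cc1` — 24%
compound 2, `Cc1nn(-c2ccccc2C(F)(F)F)c2c1C(c1ccc(Oc3ccccc3)cc1)SC(C)C(=O)N2` — 50%

Notes. In an assay on isolated protein for agonist activity at Bile acid receptor (Homo sapiens), read by AlphaScreen, with a stated time of 30 min (on this read-out lower numbers stand for smaller maximal responses and higher numbers for larger maximal responses), compound 1 gives 24% and compound 2 gives 50%. Within the data shown here, compound 1 stands lowest of the two numbers; the gap to compound 2 is beyond the scatter, though compound 2 differs from compound 1 in more than one place, so no step between them is defined and only the two values themselves can be read.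

The next compound is compound 3, `COc1cccc(-c2ccc([C@H]3S[C@@H](C)C(=O)Nc4c3c(C)nn4-c3ccccc3C)cc2)c1`. Compound 3 differs from compound 1 as follows: methoxy in place of hydrogen on an aromatic carbon. Among the measured compounds shown here, no step between measured compounds that differ in one place is available, so there is no precedent for this change.

Expectation. A modest step is expected in this assay, if anything upward, but quite possibly none beyond the scatter; the step from compound 1 to compound 3 is estimated at a number 7 percentage points higher from compound 1 to compound 3 (within the scatter). Compound 3 is therefore expected to give about 31% in this assay, within 15% to 50%.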

Compound 3, largest response reached (reported as efficacy), in percent of the reference or control that the assay uses: 41%
The estimate for compound 3 lay 10 percentage points below the measured number, and the stated range covers the measured number.
By their numbers in this assay, from the lowest: compound 1; then compounds 3 and 2 (each within the scatter of the next).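

In this assay, among these compounds, the change from phenyl to 3-methoxyphenyl is the only step that differs in one place, and it reads a number 17 percentage points higher from compound 1 to compound 3 (beyond the scatter) with the rest of the molecule unchanged. It shows that the maximal response moves with substitution on this aromatic carbon, meta to a large group, and that methoxy in place of hydrogen is accepted there with a modest gain rather than a loss. No measurement shown accounts for this step.

One group at one place leaves open whether a hydroxyl, a fluorine or a longer chain such as ethoxy on the same carbon would move the response in the same direction and by a similar amount, and whether methoxy on another carbon of this ring would do the same. Also open, from the compounds shown here alone, is whether methoxy would give a comparable step on a compound with a phenoxy group in place of the biphenyl, such as compound 2, which differs from compound 1 in more than one place.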